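Aryl swap on the five-membered ring of compound 3

The source may hold more compounds than are shown below. What is called first, only, known or untested is meant among the compounds shown, and "the series" means these compounds.

Compound 1 `CCCCCCc1cn(C(c2ccccc2)c2cc3cc(Br)ccc3nc2OC)nn1` gives 6.08% in an ADME assay on PANC-1 cells (Homo sapiens) for cytotoxicity, read by sulforhodamine B assay, with a stated time of 48 h, tested at 10 uM; on this read-out higher numbers stand for more inhibition at the one concentration tested (going by the name of the read-out) and lower numbers for less inhibition. Compound 2 `COc1nc2ccc(Br)cc2cc1C(c1ccccc1)n1cc(CCCO)nn1` gives 25.5%. Compound 3 `COc1nc2ccc(Br)cc2cc1C(c1ccccc1)n1cc(-c2ccc(F)cc2)nn1` gives 14.9%.

Compound 3 stands second highest of the three numbers: its nearest neighbour is compound 1, with a number 8.8 percentage points higher from compound 1 to compound 3 (within the scatter), and its furthest is compound 2, with a number 10.6 percentage points lower from compound 2 to compound 3 (beyond the scatter). Compound 4 `COc1nc2ccc(Br)cc2cc1C(c1ccccc1)n1cc(-c2ccccc2C(F)(F)F)nn1` has not yet been measured. It differs from compound 3 in one place: 2-(trifluoromethyl)phenyl in place of 4-fluorophenyl on an aromatic carbon.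

Both measured steps that end at compound 3 replace a chain on that aromatic carbon with the 4-fluorophenyl group, one within the scatter and one modestly beyond it. Among the measured compounds shown here, no measured step exchanges one six-membered aromatic ring of carbon only for another on that carbon, so the change from 4-fluorophenyl to 2-(trifluoromethyl)phenyl has no direct precedent here. Compound 4 is therefore expected to stay near compound 3, with a step of a number 0.1 percentage points higher from compound 3 to compound 4 (within the scatter) that is not expected to go beyond the scatter. The estimate for compound 4 is 15%, expected to lie between 4% and 28%.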

Compound 4, a percentage reported as inhibition, at one concentration (the size of the read-out at that concentration, not a potency): 11.4%
The estimate for compound 4 lay 3.6 percentage points above the measured number; low and high end bracket the measured number.
By their numbers in this assay, from the lowest: compounds 1, 4 and 3 (each within the scatter of the next); then compound 2.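

In this assay, among the compounds shown here, the first exchange of one aryl group for another on this aromatic carbon gave a number 3.5 percentage points lower from compound 3 to compound 4 (within the scatter), so 2-(trifluoromethyl)phenyl and 4-fluorophenyl cannot be told apart here. Compound 4 also reads against the two chains as compound 3 does: the 3-hydroxypropyl chain stands apart, with a number 14.1 percentage points lower from compound 2 to compound 4 (beyond the scatter), while the hexyl chain does not, with a number 5.3 percentage points higher from compound 1 to compound 4 (within the scatter) and so both aryl groups sit with hexyl rather than with the hydroxylated chain. Nothing in hand explains these numbers.

What the compounds shown leave open is whether the hydroxy group itself matters on this chain, as an amine or a carboxylic acid at its end could show. Also open, on these data alone, is whether a longer hydroxyalkyl chain or an unsubstituted phenyl group would stand with compound 2 or with the aryl compounds.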